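The source may hold more compounds than are shown below. What is called first, only, known or untested is meant among the compounds shown, and "the series" means these compounds.

Measured compounds:
compound 1 `CC(C)(C)c1ccc(CNCCCNS(=O)(=O)c2cc(C(F)(F)F)cc(C(F)(F)F)c2)cc1`: 2100 nM in a functional assay on MCF7 cells (Homo sapiens) for inhibition, read by MTT assay, with a stated time of 72 h; on this read-out higher numbers stand for weaker inhibition of growth and lower numbers for stronger inhibition of growth
compound 2 `COc1ccc(CNCCCNS(=O)(=O)c2cc(C(F)(F)F)cc(C(F)(F)F)c2)cc1OC`: 1900 nM
compound 3 `O=S(=O)(NCCCNCc1ccc(Cl)c(C(F)(F)F)c1)c1cc(C(F)(F)F)cc(C(F)(F)F)c1`: 3500 nM

Compound 3 gives the highest number of the three, but its gaps to the others stay within the scatter: a 1.7-fold higher number from compound 1 to compound 3 (0.22 log units; within the scatter) and a 1.8-fold higher number from compound 2 to compound 3 (0.27 log units; within the scatter). The remaining pair also shows no real difference: a 1.1-fold lower number from compound 1 to compound 2 (0.04 log units; within the scatter). Across these three aryl groups on the chain, this assay has not separated the compounds.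

Compound 4 `O=S(=O)(NCCCNCc1ccc(C(F)(F)F)cc1)c1cc(C(F)(F)F)cc(C(F)(F)F)c1` differs from compound 3 by 4-(trifluoromethyl)phenyl in place of 4-chloro-3-(trifluoromethyl)phenyl on a saturated chain carbon bound to an amine nitrogen. Among the measured compounds shown here, no measured step covers this exact exchange; the three aryl swaps above bear on it indirectly, and each lay within the scatter. For compound 4 no step beyond the scatter is therefore expected in this assay, in either direction. Compound 4 is estimated at 3000 nM, with a range of 1200 nM to 7500 nM, which is an expected step of a 1.2-fold lower number from compound 3 to compound 4 (0.07 log units; within the scatter).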

Compound 4, concentration for 50% growth inhibition: 1400 nM
For compound 4 the middle estimate is 2.1-fold (0.33 log units) above the measured one, and the stated range covers the measured number.
By their numbers in this assay, from the lowest: compounds 4, 2, 1 and 3 (each within the scatter of the next, the first and the last beyond it).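

In this assay, among the compounds shown here, the aryl group on a saturated chain carbon bound to an amine nitrogen separates two compounds for the first time, with a 2.5-fold lower number from compound 3 to compound 4 (0.40 log units; beyond the scatter) as a modest step for 4-(trifluoromethyl)phenyl in place of 4-chloro-3-(trifluoromethyl)phenyl. The other two aryl groups show no such separation, with a 1.4-fold lower number from compound 2 to compound 4 (0.13 log units; within the scatter) and a 1.5-fold lower number from compound 1 to compound 4 (0.18 log units; within the scatter) both within the scatter. Nothing at hand explains the step. Still open, as far as these compounds go, is whether an amine or a carboxylic acid on this aryl ring would give a larger step, and how a longer chain in the shared core would read.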